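A Mirror-Image Pair in a Cytotoxicity Test

The compounds below may be only part of what the source reports. "The series", "measured", "known", "first", "only" and "open" are said of these compounds alone.

In a functional assay on QGY cells (Homo sapiens) for cytotoxicity, read by MTT assay, with a stated time of 48 h (a higher number here means a weaker inhibitor, a lower number a stronger inhibitor), compound 1 (`CCOC(=O)[C@]1(C(=O)Nc2ccccc2)C[C@H]1c1cc(OC)c(OC)c(OC)c1`) gives > 100000 nM as a limit of the assay. Compound 2 (`COc1cc([C@H]2C[C@@]2(CO)C(=O)Nc2ccccc2)cc(OC)c1OC`) gives > 100000 nM as a limit too and not as a number. Both measured compounds thus sit at the same limit (the limit of > 100000 nM in this assay, at which 2 of the 2 values shown sit). Compound 3 (`COc1cc([C@@H]2C[C@]2(CO)C(=O)Nc2ccccc2)cc(OC)c1OC`) is the mirror image of compound 2 (the two compounds have the same atoms and bonds and differ only in configuration as drawn: 2 of 2 stereo elements differ (all stereocentres are inverted: mirror images); a stereocentre at a saturated ring carbon is drawn R in compound 2 and S in compound 3; a stereocentre at a saturated ring carbon is drawn R in compound 2 and S in compound 3), with all stereocentres inverted. Among the compounds with values here, no measured step shows what such an inversion does in this assay, so no change beyond the scatter is expected. The expected step of a number no higher from compound 2 to compound 3 (the limit leaves the size open) is therefore an estimate of no real change. For compound 3 the estimate is 100000 nM with an expected range from 30000 nM to 200000 nM in this test.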

Compound 3, half-maximal inhibitory concentration: 51300 nM
Beside the measured number, compound 3's estimate is 1.9-fold (0.29 log units) above it; measured number inside the range.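

In this assay, within the data shown here, compound 3 is the first of the three to give a number and not a limit, so inverting both stereocentres reads as an at least 1.9-fold lower number from compound 2 to compound 3 (0.28 log units; that floor lies within the scatter). Hydroxymethyl in place of ethoxycarbonyl on a saturated ring carbon reads as an at least 1.9-fold lower number from compound 1 to compound 3 (0.28 log units; that floor lies within the scatter), and neither floor goes beyond the scatter, so neither step is shown to be a real change. Any gap within this mirror-image pair could come only from configuration, because of one fact: the fact that compounds 2 and 3 differ only in the configuration as drawn. Going by these compounds, what a carboxylic acid or an aminomethyl group on that ring carbon would give stays open.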